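Swapping a Methoxy for a Methylpiperazine on a Kinase Scaffold

A few compounds are considered here, and "the series" means these few. Any claim that something is new, unique, unknown or untested is made for them only; others in the source may bear on it.

Of the compounds shown here, two sharing one core have been tested in an assay on isolated protein for inhibition of RAC-beta serine/threonine-protein kinase (Homo sapiens), read by mobility shift assay, tested at 30 uM; a higher number here means more inhibition at the concentration tested (going by the name of the read-out), a lower number less inhibition. Compound 1 `Nc1n[nH]c2cc(-c3ccncc3)[nH]c(=O)c12` carries a pyridine on the core; in this assay compound 1 gives 4%. Compound 2 `COc1ccc(-c2cc3[nH]nc(N)c3c(=O)[nH]2)cc1` carries instead a methoxy-bearing phenyl; in this assay compound 2 gives 11%. Compound 2 holds the larger of the two recorded numbers, but its gap to compound 1 is within the usual scatter, so the two cannot be told apart and both show only weak inhibition.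

Compound 3 `CN1CCN(c2ccc(-c3cc4[nH]nc(N)c4c(=O)[nH]3)cc2)CC1` is not yet measured. It differs from compound 2 in one place: 4-methylpiperazin-1-yl in place of methoxy on an aromatic carbon. Among the measured compounds shown here, no measured pair here shows what such a change does, so only a rough expectation is possible. Because compound 2 gives 11%, a small step is expected, a number 4 percentage points higher from compound 2 to compound 3 (within the scatter), no larger than the scatter. Compound 3 is therefore estimated at 15%, with a range from 0% to 40%.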

Compound 3, a percentage reported as inhibition, at one concentration (the size of the read-out at that concentration, not a potency): 6%
For compound 3 the middle estimate is 9 percentage points above the measured one, within the range that was stated.
By their numbers in this assay, from the lowest: compounds 1, 3 and 2 (each within the scatter of the next).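

Putting 4-methylpiperazin-1-yl in place of methoxy on this aromatic carbon gives, in this assay, a number 5 percentage points lower from compound 2 to compound 3 (within the scatter), so compound 2 and compound 3 cannot be told apart. Among the compounds shown here, this is the first measured change at this place, and even going from 2 heavy atoms to 7, with a six-membered non-aromatic ring added, brings no readable difference; with numbers this low at a single concentration, that says little about what the same change would do to a compound with a higher number. Nothing available explains this result.

Still open, as far as these compounds go, is whether any group on this carbon can lift the inhibition clear of the scatter. A carboxylic acid, a simple amine or a longer chain ending in an amine at the same place would test that.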